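A few compounds are considered here, and "the series" means these few. Any claim that something is new, unique, unknown or untested is made for them only; others in the source may bear on it.

Working notes on the series. The shared core carries a carboxylic acid and a benzylic link to a bromophenyl ring bearing an aryloxy-methyl group. In an assay on CHO-K1 cells for displacement of a labelled ligand from prostaglandin E2 receptor EP1 subtype (Homo sapiens) (a higher number here means a weaker inhibitor, a lower number a stronger inhibitor), compound 1, `O=C(O)c1ccn(Cc2cc(Br)ccc2OCc2ccccc2)n1`, gives 9.77 nM. Compound 2, `Cc1cc(C(=O)O)nn1Cc1cc(Br)ccc1OCc1ccc(Cl)cc1Cl`, differs from compound 1 in more than one place, so its comparison is read only from the two values: in this assay compound 2 gives 0.132 nM, the lowest of the two numbers seen so far; the number for compound 1 is far higher, well beyond the scatter.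

Compound 3, `Cc1cc(C(=O)O)nn1Cc1cc(Br)ccc1OCc1c(F)cccc1F`, is not yet measured. It differs from compound 2 in one place: 2,6-difluorophenyl in place of 2,4-dichlorophenyl on a saturated chain carbon bound to an oxygen on an aromatic ring. Among the measured compounds shown here, no measured pair here isolates this exchange, so the expectation rests on the two values known. Compound 1, which carries an unsubstituted phenyl at the same place together with another change, sits far above compound 2; the difluorophenyl of compound 3 is expected to land between those two positions, a step upward from compound 2 to compound 3 of a 7.6-fold higher number from compound 2 to compound 3 (0.88 log units; beyond the scatter), likely beyond the scatter. For compound 3 the estimated value in this assay is 1 nM, with a range from 0.2 nM to 5 nM.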

Compound 3, half-maximal inhibitory concentration: 14.8 nM
For compound 3 the middle estimate is 15-fold (1.17 log units) below the measured one; measured number above the stated range.
By their numbers in this assay, from the lowest: compound 2; then compounds 1 and 3 (each within the scatter of the next).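

Among the compounds shown here, the exchange of 2,4-dichlorophenyl for 2,6-difluorophenyl on a saturated chain carbon bound to an oxygen on an aromatic ring gives a 110-fold higher number from compound 2 to compound 3 (2.05 log units; beyond the scatter) in this assay, the first reading of a change at this position alone. The position therefore separates two dihalogenated phenyl groups sharply, even though both have 8 heavy atoms, one six-membered aromatic ring of carbon only, no hydrogen-bond donors or acceptors and no net charge, so these counts do not track the step. Nothing available here bears on the origin of this large difference.

In this single exchange, chlorine gives way to fluorine and the halogen pattern on the ring changes as well, so the compounds shown do not tell which of the two goes with the step. Also open, from the compounds shown here alone, is how the position responds to groups of another kind, such as a dibromophenyl or a pyridine ring in place of the 2,4-dichlorophenyl, and whether the step seen here would hold on a different core.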